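Swapping 1,2,3,4-tetrahydroisoquinolin-3-yl for tert-butoxy in compound 3

This account rests on a few compounds, and the source may have more. Where it says the series, first, only, none or still open, it means among the compounds named here.

- Compound 1 `CCCCCCCCCCCCCCCC(=O)N[C@@H](CCCCNC(C)=O)C(=O)N[C@@H](CCC(=O)C=[N+]=[N-])C(=O)OC(C)C`: > 50%
- Compound 2 `CC(=O)NCCCC[C@H](NC(=O)[C@@H]1Cc2ccccc2CN1)C(=O)N[C@@H](CCC(=O)C=[N+]=[N-])C(=O)OC(C)C`: 0%

Among the compounds with values here, in an ADME assay on liver (Sus scrofa) for metabolic stability, read by LC-MS, with a stated time of 1 h, tested at 10 uM (a lower number here means that less of the compound is left, a higher number that more of the compound is left), compound 2 gives 0%, the only exact number so far. Compound 1 gives > 50%, which is a limit of the assay and not an exact number.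

Compound 3 `CC(=O)NCCCC[C@H](NC(=O)OC(C)(C)C)C(=O)N[C@@H](CCC(=O)C=[N+]=[N-])C(=O)OC(C)C` has not yet been measured. It differs from compound 2 in one place: tert-butoxy in place of 1,2,3,4-tetrahydroisoquinolin-3-yl on a carbonyl carbon. Here, tert-butoxy takes the place of 1,2,3,4-tetrahydroisoquinolin-3-yl on a carbonyl carbon. Within the data shown here, no two measured compounds differ in only one place, so the size of this step cannot be read from earlier data.

Because compound 2 sits at 0% any real step in this assay can only go upward, and a rise beyond the scatter is expected. The expected step is a number 30 percentage points higher from compound 2 to compound 3 (beyond the scatter), and it is quite uncertain. For compound 3 the estimate is 30%, with an expected range from 5% to 70%.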

Compound 3, percent of the compound remaining: > 50%
Compound 3: a limit, no number; the forecaster's own chance of this, stated with the estimate: 20%; at least 20 percentage points between middle value and limit.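

Within the data shown here, this is the first comparison in which a single change can be read: in this assay, putting tert-butoxy in place of 1,2,3,4-tetrahydroisoquinolin-3-yl on a carbonyl carbon gives a number at least 50 percentage points higher from compound 2 to compound 3 (beyond the scatter). The group at this one place therefore separates a compound with none left from one with much left, while the rest of the molecule stays the same. The full size of the step cannot be read, and the reason lies in the reading for compound 3, which is a limit and not an exact number: the limit of > 50% in this assay, at which 2 of the 3 values shown sit.

The swap removes a ring-bearing group and changes several counted features at once, so the compounds shown do not tell which feature matters. On these data alone, how a simple methoxy group or a piperidine ring at the same place would behave also remains open.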